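Para-substituent swap on the benzamide of the pyrazole series

The source may report more compounds than this note shows. Statements on the series, on what has been measured and on what is new or still open speak of the compounds shown alone.

Measured so far in a functional assay on cells for positive allosteric modulation of metabotropic glutamate receptor 5 (Rattus norvegicus), read by calcium flux; on this read-out higher numbers stand for an effect only at larger amounts of compound and lower numbers for an effect already at smaller amounts: compound 1 `O=C(Nc1cc(-c2ccccc2)nn1-c1ccccc1)c1ccccc1` gives 203 nM; compound 2 `O=C(Nc1cc(-c2ccccc2)nn1-c1ccccc1)c1ccc(C(F)(F)F)cc1` gives 38 nM.

Going by the values given here, compound 2 holds the lower of the two numbers; its only neighbour is compound 1, and the step of a 5.3-fold lower number from compound 1 to compound 2 (0.73 log units; beyond the scatter) separates them, which is beyond the scatter.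

Compound 3 `O=C(Nc1cc(-c2ccccc2)nn1-c1ccccc1)c1ccc([N+](=O)[O-])cc1` is not yet measured. The change from compound 2 is nitro in place of trifluoromethyl on an aromatic carbon. Among the compounds with values here, no measured step covers this exchange: the one step in hand, a 5.3-fold lower number from compound 1 to compound 2 (0.73 log units; beyond the scatter), concerns hydrogen against trifluoromethyl at the same place, not trifluoromethyl against nitro. It shows that a group at this place matters, but gives no direction for the swap itself. The expected step from compound 2 to compound 3 is therefore kept small, a 1.3-fold higher number from compound 2 to compound 3 (0.12 log units; within the scatter), and is estimated not to exceed the scatter clearly. Compound 3 is expected to give about 50 nM, with a range from 15 nM to 170 nM.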

Compound 3, half-maximal effective concentration: 10.7 nM
For compound 3 the middle estimate is 4.7-fold (0.67 log units) above the measured one; the whole stated range lies above it.
By their numbers in this assay, from the lowest: compound 3; then compound 2; then compound 1.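

In this assay, the exchange of trifluoromethyl for nitro on this aromatic carbon, para to a large group, is not neutral: a 3.6-fold lower number from compound 2 to compound 3 (0.55 log units; beyond the scatter). The position therefore separates one substituent from another, whereas the earlier pair showed only that trifluoromethyl differs from hydrogen. Measured against hydrogen, nitro gives a 19-fold lower number from compound 1 to compound 3 (1.28 log units; beyond the scatter), the largest step in this small set, and nothing available accounts for the difference between the two groups.

Still open, as far as these compounds go, is how other groups at the same place would compare with nitro, for example an amine, a carboxylic acid, a nitrile or a longer chain such as ethyl. Equally open, from the compounds shown here alone, is whether the order of nitro, trifluoromethyl and hydrogen holds when other parts of the shared core change.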